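This account rests on a few compounds, and the source may have more. Where it says the series, first, only, none or still open, it means among the compounds named here.

Going by the values given here, compound 3 `Clc1ccc2nc(Nc3nc4ccccc4s3)sc2c1` is the one member of this small set that gives a number in a functional assay on THP-1 cells (Homo sapiens) for cytotoxicity, read by MTT assay, with a stated time of 48 h (on this read-out higher numbers stand for weaker inhibition and lower numbers for stronger inhibition), where compound 3 yields 45400 nM. Its two companions stop at the boundary of the assay. Compound 1 `Clc1cccc2sc(Nc3nc4ccccc4s3)nc12` records > 50000 nM in this assay, which is a limit and not a number. Compound 2 `Fc1ccc2nc(Nc3nc4ccccc4s3)sc2c1` likewise records > 50000 nM; > 50000 nM (2 entries) in this assay, again a limit, entered twice. The frame of the picture is therefore (the limit of > 50000 nM in this assay, at which 1 of the 3 values shown sits), and compound 3 sits only a little short of it.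

Compound 4 `c1ccc2sc(Nc3nc4ccccc4s3)nc2c1` shares the core of compound 3 and differs from it by hydrogen in place of chloro on an aromatic carbon. Among the compounds with values here, no step between two measured compounds is available to guide the reading, so the change from compound 3 to compound 4 is expected to be small in this assay, tending if anything toward weaker inhibition, or to stay within the scatter altogether. Compound 4 is accordingly expected at about 60000 nM, within a range of 20000 nM to 200000 nM. The estimated step of a 1.3-fold higher number from compound 3 to compound 4 (0.12 log units; within the scatter) is expected to be modest, with a fair chance that only a limit is reported.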

Compound 4, half-maximal inhibitory concentration: 28800 nM
The estimate for compound 4 lay 2.1-fold (0.32 log units) above the measured number; low and high end bracket the measured number.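

In this assay, the exchange at this place gives a 1.6-fold lower number from compound 3 to compound 4 (0.20 log units; within the scatter), so the chloro group on this aromatic carbon, meta to a fused ring and para to a fused ring, can be replaced by hydrogen without a change that stands out from the scatter. The same exchange read from the other chloro compound gives an at least 1.7-fold lower number from compound 1 to compound 4 (0.23 log units; that floor lies within the scatter), and this too does not establish a difference beyond the scatter. That second step rests on a limit of compound 1 and not on a number: the limit of > 50000 nM in this assay, at which 1 of the 4 values shown sits.

The compounds shown leave open whether a different group at this place, such as an amine, a carboxylic acid or a longer chain, would move the number beyond the scatter. They also leave open whether any change elsewhere on the shared core would do so.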